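Chloro in place of iodo: expecting compound 4

The compounds below may be only part of what the source reports. "The series", "measured", "known", "first", "only" and "open" are said of these compounds alone.

Three compounds have been measured in an ADME assay on RAW264.7 cells (Mus musculus) for cytotoxicity, read by MTT assay, with a stated time of 24 h; a lower number here means that less compound is tolerated, a higher number that more compound is tolerated:
compound 1, `O=C(Nc1ccc(Cl)cc1F)c1cc(I)ccc1O`, gives 8500 nM;
compound 2, `O=c1oc2ccc(Br)cc2c(=O)n1-c1ccc(F)cc1F`, gives 16000 nM;
compound 3, `O=C(Nc1ccc(I)cc1F)c1cc(I)ccc1O`, gives 6000 nM.

The number for compound 1 sits within the usual scatter of both others. Its difference to compound 3 is a 1.4-fold lower number from compound 1 to compound 3 (0.15 log units; within the scatter), and the numbers of compound 1 and compound 2 likewise lie close enough that no order between the three can be read from them.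

Compound 4, `O=C(Nc1ccc(Cl)cc1F)c1cc(Cl)ccc1O`, differs from compound 1 by chloro in place of iodo on an aromatic carbon. Among the compounds with values here, the only measured step that bears on this is a 1.4-fold lower number from compound 1 to compound 3 (0.15 log units; within the scatter), the same pair of groups exchanged in the opposite direction, and it stayed within the scatter. No step beyond the scatter is therefore expected in this assay . For compound 4 the estimate is 8500 nM, with a range from 4000 nM to 18000 nM. The step this expectation means is no change at the digits printed from compound 1 to compound 4 (within the scatter), which is no change beyond the scatter.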

Compound 4, half-maximal cytotoxic concentration: 8000 nM
Compound 4: the middle estimate sits 1.1-fold (0.03 log units) above what was measured; measured number inside the range.
By their numbers in this assay, from the lowest: compounds 3, 4, 1 and 2 (each within the scatter of the next, the first and the last beyond it).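

In this assay, the iodo group para to a hydroxy group can be replaced by chloro with only a 1.1-fold lower number from compound 1 to compound 4 (0.03 log units; within the scatter). Within the data shown here, the earlier step changed a halogen elsewhere in the molecule, so this is the first direct reading at this position, and this exchange also stays within the usual scatter. Both halogen exchanges shown therefore leave the tolerated concentration without a readable change, and no measurement offered here explains this result.

Iodo and chloro each count as a single heavy atom with no ring and no hydrogen-bond donors or acceptors, so this step says little about groups of a different kind. As far as these compounds go, whether an amine, a carboxylic acid or a longer chain at this position would also stay within the scatter remains open.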